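Swapping methyl for cyclohexyl on the shared core

A few compounds are considered here, and "the series" means these few. Any claim that something is new, unique, unknown or untested is made for them only; others in the source may bear on it.

Compound 2 `COc1cc2nc(C)cc(NCC3CCN(c4ncc(C(=O)NO)cn4)CC3)c2cc1OC` gives the lower of two numbers in an assay on isolated protein for inhibition of protein deacetylase HDAC6 (Homo sapiens), read by fluorescence, with a stated time of 30 min (on this read-out higher numbers stand for weaker inhibition and lower numbers for stronger inhibition), with 253 nM. Compound 1 `COc1cc2c(NCC3CCN(c4ncc(C(=O)NO)cn4)CC3)cc(C)nc2cc1OCCCN1CCCC1` gives 350 nM; the step of a 1.4-fold lower number from compound 1 to compound 2 (0.14 log units; within the scatter) changes only the group on a saturated chain carbon bound to an oxygen on an aromatic ring, not the aromatic carbon altered in compound 3. Compound 3 `COc1cc2nc(C3CCCCC3)cc(NCC3CCN(c4ncc(C(=O)NO)cn4)CC3)c2cc1OC` differs from compound 2 in one place: cyclohexyl in place of methyl on an aromatic carbon. Among the measured compounds shown here, no measured step touches this aromatic carbon, so the single measured step cannot guide size or direction here; it shows only that a change elsewhere left the number within the scatter. With that, the expectation for compound 3 in this assay is a step of no more than the scatter in either direction, a 1.2-fold higher number from compound 2 to compound 3 (0.07 log units; within the scatter). The estimated value for compound 3 is 300 nM, with a range from 110 nM to 850 nM.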

Compound 3, half-maximal inhibitory concentration: 111 nM
Compound 3: middle estimate off by 2.7-fold (0.43 log units), on the high side; the range from low to high includes it.
By their numbers in this assay, from the lowest: compound 3; then compounds 2 and 1 (each within the scatter of the next).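

Replacing methyl with cyclohexyl on the aromatic carbon next to the ring nitrogen gives a 2.3-fold lower number from compound 2 to compound 3 (0.36 log units; beyond the scatter) in this assay. This position therefore accepts a group of six carbons in a non-aromatic ring in place of a single carbon, with stronger inhibition, and this modest step lies beyond the scatter, whereas the earlier change on the chain carbon bound to oxygen stayed within it. Nothing available here accounts for the lower number.

As far as these compounds go, with only methyl and cyclohexyl to compare at this carbon, it remains open whether the lower number goes with the ring itself or simply with the added carbons, which an open chain such as n-hexyl or a flat ring such as phenyl could help to separate. From the compounds shown here alone, it is also open whether cyclohexyl would give a similar step with the 2-(pyrrolidin-1-yl)ethyl group of compound 1 on the oxygen-bound chain.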